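From 1-hydroxyethyl to dimethylcarbamoyl on the side chain

The source may report more compounds than this note shows. Statements on the series, on what has been measured and on what is new or still open speak of the compounds shown alone.

Among the measured compounds shown here, in a functional assay on NCI-H2286 cells (Homo sapiens) for antiproliferative activity, read by CCK-8 assay, with a stated time of 72 h (a higher number here means a weaker inhibitor, a lower number a stronger inhibitor), compound 1 `Cc1ccc(C(=O)Nc2cccc(C(F)(F)F)c2)cc1-c1ccc2c(-c3cnn(C)c3)n[nH]c2c1` gives 24.3 nM, and compound 2 `Cc1ccc(C(=O)Nc2cccc(C(F)(F)F)c2)cc1-c1ccc2c(-c3cnn(CC(C)O)c3)n[nH]c2c1` gives 196 nM, the higher of the two numbers so far. Compound 3 `Cc1ccc(C(=O)Nc2cccc(C(F)(F)F)c2)cc1-c1ccc2c(-c3cnn(CC(=O)N(C)C)c3)n[nH]c2c1` carries dimethylcarbamoyl in place of 1-hydroxyethyl on a saturated chain carbon bound to an aromatic nitrogen. For the measured compounds named here, only one measured step bears on this place: an 8.1-fold higher number from compound 1 to compound 2 (0.91 log units; beyond the scatter), a modest step in which 1-hydroxyethyl entered there. Going by the values given here, no measured compound carries dimethylcarbamoyl, so this single step is weak guidance. Given an 8.1-fold higher number from compound 1 to compound 2 (0.91 log units; beyond the scatter), a partial move back towards the lower number is expected, of modest size and with no certainty that it clears the scatter. The expected step is a 2.8-fold lower number from compound 2 to compound 3 (0.45 log units; beyond the scatter). For compound 3 the estimate is 70 nM, with an expected range of 22 nM to 220 nM.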

Compound 3, half-maximal inhibitory concentration: > 1000 nM
Compound 3: no number, only a limit (the forecaster's own chance of this, stated with the estimate: 2%); at least 14-fold (1.15 log units) between middle value and limit.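

In this assay compound 3 has no number, only a limit of the assay: the limit of > 1000 nM in this assay, at which 1 of the 3 values shown sits.

Putting dimethylcarbamoyl in place of 1-hydroxyethyl on a saturated chain carbon bound to an aromatic nitrogen gives an at least 5.1-fold higher number from compound 2 to compound 3 (0.70 log units; beyond the scatter), so this replacement moves further from compound 1 rather than back towards it. Measured against the smaller group, the same change reads as an at least 41-fold higher number from compound 1 to compound 3 (1.61 log units; beyond the scatter), which places both extended side chains on the weak side of compound 1, with dimethylcarbamoyl the further out.

From the compounds shown here alone, how far compound 3 lies past its limit stays open, as does which part of dimethylcarbamoyl goes with the loss. Also open, going by these compounds, is whether a carboxylic acid, a primary amide or a longer chain ending in an amine at this place would stand nearer to compound 1.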